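Aromatic nitrogen substituent variation in the shared core

The source may report more compounds than this note shows. Statements on the series, on what has been measured and on what is new or still open speak of the compounds shown alone.

Three measured compounds share one core and differ only in the group on an aromatic nitrogen. Compound 1 `CCc1ccc(-n2nc(-c3ccc(C(F)(F)F)cc3O)nc2-c2ccccc2O)cc1` carries a 4-ethylphenyl there, and in a functional assay on PC-12 cells (Rattus norvegicus) for cytotoxicity, read by MTT assay, with stated times of 2 h and 24 h, tested at 1 uM (on this read-out higher numbers stand for a stronger effect at the one concentration tested and lower numbers for a weaker effect), compound 1 gives 64.4%. Compound 2 `Oc1cc(C(F)(F)F)ccc1-c1nc(-c2ccccc2O)n(-c2ccccc2F)n1` carries a 2-fluorophenyl, and in this assay compound 2 gives 63.4%; the step is a number 1 percentage points lower from compound 1 to compound 2 (within the scatter). Compound 3 `Oc1cc(C(F)(F)F)ccc1-c1nc(-c2ccccc2O)n(-c2cccc(C(F)(F)F)c2)n1` carries a 3-(trifluoromethyl)phenyl, and in this assay compound 3 gives 71.5%, the highest of the three numbers shown, though a number 7.1 percentage points higher from compound 1 to compound 3 (within the scatter) and a number 8.1 percentage points higher from compound 2 to compound 3 (within the scatter) both stay within the scatter, so no order among the three can be read from these values.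

Compound 4 `Oc1cc(C(F)(F)F)ccc1-c1nc(-c2ccccc2O)n(-c2cc(F)cc(F)c2)n1` continues the same exchange: 3,5-difluorophenyl in place of 3-(trifluoromethyl)phenyl on an aromatic nitrogen. For the measured compounds named here, the steps that bear on it are the two that already replaced the group on this nitrogen, a number 7.1 percentage points higher from compound 1 to compound 3 (within the scatter) and a number 8.1 percentage points higher from compound 2 to compound 3 (within the scatter); neither went beyond the scatter, and the entering group is again a single six-membered aromatic ring of carbon only with no donors or acceptors. The expected step is therefore a number 5.5 percentage points lower from compound 3 to compound 4 (within the scatter), nothing beyond the scatter in either direction. Compound 4 is estimated at 66%, with a range from 55% to 77%.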

Compound 4, a percentage reported as activity, at one concentration (the size of the read-out at that concentration, not a potency): 75.5%
Beside the measured number, compound 4's estimate is 9.5 percentage points below it, and the stated range covers the measured number.
By their numbers in this assay, from the lowest: compounds 2, 1, 3 and 4 (each within the scatter of the next, the first and the last beyond it).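

For the compounds shown here, compound 4 is the first whose gaps to other members pass the scatter, with a number 12.1 percentage points higher from compound 2 to compound 4 (beyond the scatter) and a number 11.1 percentage points higher from compound 1 to compound 4 (beyond the scatter), whereas every step among compounds 1, 2 and 3 stayed within it. The exchange on this nitrogen can therefore shift the number in this assay, but only modestly, and compound 3 does not share that separation from compounds 1 and 2, while a number 4 percentage points higher from compound 3 to compound 4 (within the scatter) leaves 3,5-difluorophenyl and 3-(trifluoromethyl)phenyl indistinguishable here. Nothing available explains why these groups give the numbers they do.

All of these comparisons rest on one concentration, so they describe the size of the read-out at that concentration and say nothing about potency, and the separation of compound 4 from compounds 1 and 2 remains a modest one. Open too is how the number would respond if the group on this nitrogen carried an amine or a carboxylic acid, or if a longer alkyl chain took the place of the aromatic ring, since every group shown here is a phenyl ring bearing only fluorine, trifluoromethyl or ethyl.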